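The source may report more compounds than this note shows. Statements on the series, on what has been measured and on what is new or still open speak of the compounds shown alone.

The measured compounds in a toxicity assay on BJ cells (Homo sapiens) for cytotoxicity, read by MTT assay, with a stated time of 24 h; a lower number here means a stronger inhibitor, a higher number a weaker inhibitor:

Compound 1, `CCOC(=O)N1CCC(=NNC(=O)c2ccc(Cl)cc2)CC1`, gives > 400000 nM, which is a limit of the assay and not a number.
Compound 2, `CCOC(=O)N1CCC(=NNC(=O)c2ccc(C)cc2)CC1`, gives > 400000 nM, again a limit of the assay.
Compound 3, `O=C(NN=C1CC(c2ccccc2)NC(c2ccccc2)C1)c1ccc(F)cc1`, gives > 400000 nM, likewise a limit of the assay.

Compound 3 therefore stands where every measured compound stands, at the limit of > 400000 nM in this assay, at which 3 of the 3 values shown sit. Within the data shown here, the only step between two measured compounds that differ in one place, a step that the two limits leave unreadable from compound 1 to compound 2, has a methyl in place of a chloro on an aromatic carbon, and the two limits leave its size unreadable.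

Compound 4, `O=C(NN=C1CC(c2ccccc2)NC(c2ccccc2)C1)c1ccc([N+](=O)[O-])cc1`, differs from compound 3 by nitro in place of fluoro on an aromatic carbon. Among the measured compounds shown here, no measured step involves a nitro group, and the one measured step bears on this change only in that it shows nothing beyond the limit on either side. Nothing in the values of compounds 1, 2 and 3 suggests that the step from compound 3 to compound 4 in this assay will be readable, and the step is expected to be a number no higher from compound 3 to compound 4 (the limit leaves the size open), with a limit the most likely outcome. Compound 4 is accordingly estimated at 400000 nM in this assay, with a range from 200000 nM to 800000 nM.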

Compound 4, half-maximal inhibitory concentration: > 400000 nM
Compound 4 was reported as a limit (the forecaster's own chance of this, stated with the estimate: 85%); the middle value sits exactly at the limit.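

In this assay compound 4 gives > 400000 nM, which is a limit of the assay and not a number. Compound 3 also stands at a limit, so no step can be read between compound 3 and compound 4. The compounds shown leave open what number any of them would give in this assay, and whether any change among them moves it: the limit of > 400000 nM in this assay, at which 4 of the 4 values shown sit.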